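Swapping the Chain on the Shared Core of Compound 2

A few compounds are considered here, and "the series" means these few. Any claim that something is new, unique, unknown or untested is made for them only; others in the source may bear on it.

In a functional assay on PANC-1 cells (Homo sapiens) for inhibition, read by MTT assay, with a stated time of 24 h, tested at 10 uM (a higher number here means more inhibition at the concentration tested (going by the name of the read-out), a lower number less inhibition), compound 1 `CC(C)=CCC/C(C)=C/CC1Cc2c(OCCCNS(=O)(=O)c3ccc(Cl)cc3)cc(=O)n(CCCO)c2CC1(C)C` gives 14.5%.
In this assay, compound 2 `CC(C)=CCC/C(C)=C/CC1Cc2c(OCCCNC(=O)c3ccco3)cc(=O)n(CCCO)c2CC1(C)C` gives 69.5%.
In this assay, compound 3 `CC(C)=CCC/C(C)=C/CC1Cc2c(OCCCOc3ccc([N+](=O)[O-])cc3)cc(=O)n(CCCO)c2CC1(C)C` gives 65.1%.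

Compound 2 and compound 3 cannot be told apart on these numbers a number 4.4 percentage points lower from compound 2 to compound 3 (within the scatter), and both stand well above compound 1 a number 55 percentage points higher from compound 1 to compound 2 (beyond the scatter) a number 50.6 percentage points higher from compound 1 to compound 3 (beyond the scatter). The only lesson so far is that the group at the far end of the three-carbon chain can shift the read-out a great deal, while two quite different ends gave the same result.

Compound 4 `CC(C)=CCC/C(C)=C/CC1Cc2c(OC(=O)Nc3ccc(F)cc3)cc(=O)n(CCCO)c2CC1(C)C` takes a different kind of step: (4-fluorophenyl)carbamoyl in place of 3-(((furan-2-yl)carbonyl)amino)propyl on an oxygen on an aromatic ring. Here the whole chain leaves and a short group enters directly on the ring oxygen. Among the compounds with values here, no measured step removes the chain, so the two large steps only show how much this region can matter, not which way a chain-free compound goes. A drop of moderate size in this assay is expected, with wide uncertainty a number 24.5 percentage points lower from compound 2 to compound 4 (beyond the scatter). Compound 4 is estimated at 45%, between 15% and 75%.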

Compound 4, a percentage reported as inhibition, at one concentration (the size of the read-out at that concentration, not a potency): 43.9%
Compound 4: middle estimate off by 1.1 percentage points, on the high side; the range from low to high includes it.
By their numbers in this assay, from the lowest: compound 1; then compound 4; then compounds 3 and 2 (each within the scatter of the next).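

With the chain gone from the ring oxygen and a (4-fluorophenyl)carbamoyl group in its place, the read-out in this assay falls by a clear margin, a number 25.6 percentage points lower from compound 2 to compound 4 (beyond the scatter), yet compound 4 still gives 43.9%, so the three-carbon chain is not needed for some inhibition at this position. The leaving and entering groups are close in heavy-atom count and each holds one aromatic ring, so a change of similar bulk on this oxygen can still move the number beyond the scatter. No measurement here explains this drop.

The step changes the chain, the link and the ring at once, so the compounds shown cannot say which of these matters. Going by these compounds, how a longer chain, or a propyl chain ending in an amine or a carboxylic acid, would read at this oxygen remains open.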